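The source may hold more compounds than are shown below. What is called first, only, known or untested is meant among the compounds shown, and "the series" means these compounds.

Measured in a functional assay on MCF7 cells (Homo sapiens) for cytotoxicity, read by MTT assay, with a stated time of 72 h; a higher number here means a weaker inhibitor, a lower number a stronger inhibitor:
- Compound 1 `CS(=O)(=O)Oc1c(C(=O)NCc2ccc(F)cc2)nc(Br)c2cccnc12`: "not determined" (no result reported)
- Compound 2 `NCCCNc1c(C(=O)NCc2ccc(F)cc2)nc(Br)c2cccnc12`: 6000 nM
- Compound 3 `Nc1ccc(Nc2c(C(=O)NCc3ccc(F)cc3)nc(Br)c3cccnc23)cc1`: 4000 nM

In this assay compound 3 gives 4000 nM. Among the compounds with values here, the only other number, 6000 nM for compound 2, lies within the scatter of it, and compound 1 offers no number for comparison.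

Compound 4 `CN(C)CCCNc1c(C(=O)NCc2ccc(F)cc2)nc(Br)c2cccnc12` has not yet been measured. Its difference from compound 3 is this: 3-(dimethylamino)propyl in place of 4-aminophenyl on a nitrogen on an aromatic ring. Thus 3-(dimethylamino)propyl replaces 4-aminophenyl on the same nitrogen.

Within the data shown here, one measured step bears on this change: a 1.5-fold lower number from compound 2 to compound 3 (0.18 log units; within the scatter). It exchanges 3-aminopropyl for 4-aminophenyl at that nitrogen and stays within the scatter. Among the measured compounds shown here, no measured compound carries the 3-(dimethylamino)propyl group, so the data leave that group itself untested, and the range must stay wide. No step beyond the scatter is expected, in either direction.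

The estimate amounts to an expected 1.1-fold higher number from compound 3 to compound 4 (0.05 log units; within the scatter). For compound 4 the expected value in this assay is 4500 nM, with an estimated range of 1800 nM to 11000 nM.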

Compound 4, half-maximal inhibitory concentration: 7000 nM
For compound 4 the middle estimate is 1.6-fold (0.19 log units) below the measured one, and the stated range covers the measured number.
By their numbers in this assay, from the lowest: compounds 3, 2 and 4 (each within the scatter of the next).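

In this assay, 3-(dimethylamino)propyl in place of 4-aminophenyl on this nitrogen gives a 1.8-fold higher number from compound 3 to compound 4 (0.24 log units; within the scatter), so all three groups seen here, 4-aminophenyl, 3-aminopropyl and 3-(dimethylamino)propyl, remain within the scatter of one another. The change on the chain itself, dimethylamino in place of amino, gives a 1.2-fold higher number from compound 2 to compound 4 (0.07 log units; within the scatter), so this first change at the far end of the chain also shows no step beyond the scatter. Nothing shown bears on why these numbers fall as they do.

Going by these compounds, it remains open whether a longer chain on this nitrogen would give a step beyond the scatter. A carboxylic acid or a hydroxyl group in place of the amine on the chain is equally unresolved, as is a morpholine ring.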